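A few compounds are considered here, and "the series" means these few. Any claim that something is new, unique, unknown or untested is made for them only; others in the source may bear on it.

Compound 1 `Cc1cn([C@@H]2CC[C@H](CO)O2)c(=O)nc1N` gives 1550000 nM in an ADME assay on HepG2 cells (Homo sapiens) for cytotoxicity, read by MTT assay, with a stated time of 3 days; a lower number here means that less compound is tolerated, a higher number that more compound is tolerated. For compound 2 `Cc1cn([C@@H]2C[C@@H](O)[C@H](CO)O2)c(=O)nc1N` this assay reports only a limit, > 2000000 nM. Compound 3 `Cc1cn([C@@H]2C[C@@H](O)[C@H](CO)O2)c(=O)nc1NO` gives 490000 nM. Compound 2 therefore stands only as a limit, at the limit of > 2000000 nM in this assay, at which 1 of the 3 values shown sits. Compound 4 `Cc1cn([C@@H]2C[C@@H](F)[C@H](CO)O2)c(=O)nc1N` differs from compound 2 by fluoro in place of hydroxy on a saturated ring carbon. Two measured steps exist: an at least 1.2-fold higher number from compound 1 to compound 2 (0.11 log units; that floor lies within the scatter), and an at least 4.0-fold lower number from compound 2 to compound 3 (0.61 log units; beyond the scatter). Only the first concerns the same saturated ring carbon, and it lies within the scatter. With fluoro in place of hydroxy there, and compound 2 offering only a limit, no step beyond the scatter is expected in this assay. Compound 4 is therefore estimated at 1500000 nM, between 500000 nM and 3000000 nM. The expected step is an at least 1.3-fold lower number from compound 2 to compound 4 (0.12 log units; that floor lies within the scatter).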

Compound 4, half-maximal cytotoxic concentration: 1800000 nM
Beside the measured number, compound 4's estimate is 1.2-fold (0.08 log units) below it, and the stated range covers the measured number.
By their numbers in this assay, from the lowest: compound 3; then compounds 1 and 4 (each within the scatter of the next). At a limit, above all of these: compound 2.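

Fluoro in place of hydroxy on this saturated ring carbon gives an at least 1.1-fold lower number from compound 2 to compound 4 (0.04 log units; that floor lies within the scatter). Fluoro in place of hydrogen at the same carbon gives a 1.2-fold higher number from compound 1 to compound 4 (0.06 log units; within the scatter), so in this assay neither step on this carbon is shown to lie beyond the scatter. The full size of the change from hydroxy cannot be fixed, because compound 2 stands only as a limit: the limit of > 2000000 nM in this assay, at which 1 of the 4 values shown sits.

The compounds shown leave open whether an amine or an azide on this carbon would give a step beyond the scatter. They also leave open whether hydroxy on the aromatic ring nitrogen, as in compound 3, would give a similar step alongside fluoro.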